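The source may hold more compounds than are shown below. What is called first, only, known or untested is meant among the compounds shown, and "the series" means these compounds.

Measured compounds:
compound 1 `C=C(CC)C(=O)c1ccc(OCC(=O)NCCNS(=O)(=O)c2ccc(OC)cc2)c(Cl)c1Cl` with 860 nM in a functional assay on HL-60 cells (Homo sapiens) for cytotoxicity, read by luminescence; a higher number here means a weaker inhibitor, a lower number a stronger inhibitor;
compound 2 `C=C(CC)C(=O)c1ccc(OCC(=O)NCCNS(=O)(=O)c2ccc(OC)cc2OC)c(Cl)c1Cl` with 2790 nM in this assay;
compound 3 `C=C(CC)C(=O)c1ccc(OCC(=O)N2CCN(S(=O)(=O)c3ccc(OC)cc3)CC2)c(Cl)c1Cl` with 590 nM in this assay.

Compound 3 gives the lowest of the three numbers, though its gap to compound 1 is within the scatter, while compound 2 sits furthest from it. The difference between the core of compound 1 and the core of compound 3 is not broken down here. Within the core of compound 1, the change methoxy in place of hydrogen on an aromatic carbon gave a 3.2-fold higher number from compound 1 to compound 2 (0.51 log units; beyond the scatter). Compound 4 `C=C(CC)C(=O)c1ccc(OCC(=O)N2CCN(S(=O)(=O)c3ccc(OC)cc3OC)CC2)c(Cl)c1Cl` carries the same change on the core of compound 3, (methoxy in place of hydrogen on an aromatic carbon). Within the data shown here, because the earlier step was a 3.2-fold higher number from compound 1 to compound 2 (0.51 log units; beyond the scatter), compound 4 is expected to show a step of similar size, a 2.9-fold higher number from compound 3 to compound 4 (0.46 log units; beyond the scatter), though only one prior instance supports this. The estimate for compound 4 is therefore 1700 nM, between 700 nM and 4200 nM.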

Compound 4, half-maximal inhibitory concentration: 3190 nM
Estimate against measurement, compound 4: 1.9-fold (0.27 log units) below; measured number inside the range.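

In this assay, the change from 4-methoxyphenyl to 2,4-dimethoxyphenyl gave a 5.4-fold higher number from compound 3 to compound 4 (0.73 log units; beyond the scatter), so the number rose on this core as it had on the core of compound 1. The two steps agree in direction and, within the scatter, in size, so the change carried over between these two cores: the same change on two cores in this assay, a 3.2-fold higher number (0.51 log units; beyond the scatter) from compound 1 to compound 2 and a 5.4-fold higher number (0.73 log units; beyond the scatter) from compound 3 to compound 4, 1.7-fold (0.22 log units) apart, within the scatter of two such steps. This rests on just two pairs of compounds, however, and it shows neither why the number rises nor that the step would hold on any further core.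

The compounds shown leave open whether an amine, a carboxylic acid or a longer alkoxy chain in place of this methoxy would give a step of similar size. They also leave open how a methoxy group elsewhere on this ring would behave.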